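Chloro in Place of Methyl: What to Expect

A few compounds are considered here, and "the series" means these few. Any claim that something is new, unique, unknown or untested is made for them only; others in the source may bear on it.

Compound 2 `Cc1cc(N)cc(Cl)c1-c1nc2ccccc2s1` is known only as a limit: in a functional assay on MDA-MB-468 cells (Homo sapiens) for inhibition (on this read-out higher numbers stand for weaker inhibition and lower numbers for stronger inhibition), compound 2 gives > 1 nM. Compound 1 `Nc1ccc(-c2nc3ccccc3s2)c(Cl)c1` also sits at a limit, giving < 0.1 nM in this assay. Going by the values given here, the only measured step, an at least 10-fold higher number from compound 1 to compound 2 (1.00 log units; beyond the scatter), shows that adding a methyl weakens inhibition. Compound 3 `Nc1cc(Cl)c(-c2nc3ccccc3s2)c(Cl)c1` differs from compound 2 by chloro in place of methyl on an aromatic carbon. Among the compounds with values here, no measured step swaps one small group for another, so a change of similar size is not expected. Compound 3 is estimated at 3 nM (range 0.7 nM to 15 nM), which means an expected step that the limit leaves unreadable from compound 2 to compound 3 that stays within the scatter.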

Compound 3, half-maximal inhibitory concentration: < 0.1 nM
Compound 3: no number, only a limit; the forecaster's own chance of this, stated with the estimate: 30%; middle value at least 30-fold (1.47 log units) away from the limit.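

At this position, on an aromatic carbon ortho to a group of 9 heavy atoms, chloro in place of methyl gives an at least 10-fold lower number from compound 2 to compound 3 (1.00 log units; beyond the scatter) in this assay. The earlier compounds shown here showed only that methyl weakens inhibition here; now it is clear that not every group at this position does so. The step between compound 1 and compound 3 cannot be read, because both sit at the same limit: the limit of < 0.1 nM in this assay, at which 2 of the 3 values shown sit.

Still open, from the compounds shown here alone, is how a fluoro, a methoxy or an amine at this position would behave.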